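The compounds below may be only part of what the source reports. "The series", "measured", "known", "first", "only" and "open" are said of these compounds alone.

The shared core appears in compound 1 `COc1ccc(-c2ncnn2-c2cc(OC)c(OC)c(OC)c2)cc1`, and in a functional assay on Jurkat cells (Homo sapiens) for antiproliferative activity, read by MTT assay, with a stated time of 72 h (a higher number here means a weaker inhibitor, a lower number a stronger inhibitor), compound 1 gives 50 nM. Compound 2 `COc1cc(-n2ncnc2-c2ccccc2)cc(OC)c1OC` reaches only a limit of this assay, and compound 2 gives > 10000 nM. Compound 3 `COc1cc(-n2ncnc2-c2cccc(Cl)c2)cc(OC)c1OC` likewise returns only a limit: in this assay compound 3 gives > 10000 nM. Compound 3 therefore stands at the limit of > 10000 nM in this assay, at which 2 of the 3 values shown sit, with no number known for it.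

Among the compounds with values here, two measured steps bear on what follows. The change of hydrogen in place of methoxy on an aromatic carbon brought an at least 200-fold higher number from compound 1 to compound 2 (2.30 log units; beyond the scatter), and 3-chlorophenyl in place of 4-methoxyphenyl brought an at least 200-fold higher number from compound 1 to compound 3 (2.30 log units; beyond the scatter). Between the two limits, a step that the two limits leave unreadable from compound 2 to compound 3.

Compound 4 `CCOc1ccc(-c2ncnn2-c2cc(OC)c(OC)c(OC)c2)cc1Cl` differs from compound 3 by ethoxy in place of hydrogen on an aromatic carbon. This ethoxy returns an alkoxy to the position emptied from compound 1 to compound 2, so because an at least 200-fold higher number from compound 1 to compound 2 (2.30 log units; beyond the scatter) was large, a large move in the opposite direction is expected: an at least 50-fold lower number from compound 3 to compound 4 (1.69 log units; beyond the scatter). Compound 4 is estimated at 200 nM, within 20 nM to 3000 nM.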

Compound 4, half-maximal inhibitory concentration: 3 nM
Estimate against measurement, compound 4: 67-fold (1.82 log units) above, outside the stated range (below it).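

In this assay, ethoxy in place of hydrogen, on the aromatic carbon ortho to a chloro group and para to a large group, brought an at least 3300-fold lower number from compound 3 to compound 4 (3.52 log units; beyond the scatter). Within the data shown here, the earlier compounds showed only that the values reached a limit when this position carried hydrogen. This step shows that the position can also take ethoxy with the chloro group present, and compound 4 then gives 3 nM. The printed step is only a bound, since compound 3 provides a limit and not a number: the limit of > 10000 nM in this assay, at which 2 of the 4 values shown sit.

Going by these compounds, how a longer chain such as propoxy, or an amine, would behave at this position remains open. The compounds shown also leave open what the chloro group itself contributes when ethoxy is present.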